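Stilbene series: fluoro for methyl on the aryl ring

The source may hold more compounds than are shown below. What is called first, only, known or untested is meant among the compounds shown, and "the series" means these compounds.

Measured compounds, all in a functional assay on MOLT-4 cells (Homo sapiens), read by cell counting, with a stated time of 72 h; a lower number here means a stronger inhibitor, a higher number a weaker inhibitor:
- compound 1 `Cc1ccc(/C=C/c2ccccc2F)cc1` gives 30 ug/mL
- compound 2 `Fc1ccc(/N=C/c2cccs2)cc1Cl` gives 16 ug/mL
- compound 3 `Fc1ccc(/N=C/c2ccccc2Cl)cc1` gives 0.77 ug/mL

Compound 1 gives the highest of the three numbers in this assay. Its gap to compound 2 lies within the usual scatter, so the two cannot be placed in an order. Compound 3 gives a much lower number, and that gap lies beyond the scatter. Compounds 2 and 3 carry an imine linker rather than the alkene of compound 1, so they offer no direct reading of the change examined here.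

The next compound, compound 4 `Fc1ccc(/C=C/c2ccccc2F)cc1`, differs from compound 1 in one place: fluoro in place of methyl on an aromatic carbon. Both groups are single heavy atoms with no ring, no hydrogen-bond donor or acceptor and no charge.

Within the data shown here, no measured pair in this set shows this exchange, and the two imines do not isolate it. The step from compound 1 to compound 4 is therefore expected to be small, with no direction beyond the scatter, and a 1.2-fold lower number from compound 1 to compound 4 (0.08 log units; within the scatter) is the estimate for it. For compound 4 the expected value in this assay is 25 ug/mL, with a range from 8 ug/mL to 70 ug/mL.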

Compound 4, half-maximal inhibitory concentration: 61 ug/mL
The estimate for compound 4 lay 2.4-fold (0.39 log units) below the measured number; measured number inside the range.
By their numbers in this assay, from the lowest: compound 3; then compounds 2 and 1 (each within the scatter of the next); then compound 4.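

In this assay, among these compounds, the exchange of methyl for fluoro on this aromatic carbon is the first single-place change that can be read, and it gives a 2.0-fold higher number from compound 1 to compound 4 (0.31 log units; beyond the scatter) for this pair. The position is therefore not indifferent to the exchange: two groups that match in heavy-atom count, and that both have no ring, no hydrogen-bond donor or acceptor and no charge, still separate here, with methyl giving the lower number. The step is modest and rests on this single pair, and nothing measured here accounts for it.

Still open, from the compounds shown here alone, is whether the same exchange would shift the number in the same direction in the imine compounds, since compound 2 and compound 3 do not isolate it. Also open, going by these compounds, is how a methoxy group, an amine or a carboxylic acid on this aromatic carbon would compare with methyl and fluoro, and so whether any group here can bring the stilbene series to a lower number than methyl does.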